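Chloro for methyl on the outer ring across two cores

The source may report more compounds than this note shows. Statements on the series, on what has been measured and on what is new or still open speak of the compounds shown alone.

Compound 1 `Cc1cccc(-c2nc3c(=O)[nH]c(C)nc3s2)c1` gives 1% in an assay on CHO cells for displacement of a labelled ligand from adenosine receptor A1 (Homo sapiens), read by scintillation counting, with a stated time of 120 min, tested at 1 uM (a lower number here means less inhibition, a higher number more inhibition at the concentration tested (going by the name of the read-out)), while compound 2 `Cc1nc2sc(-c3cccc(Cl)c3)nc2c(=O)[nH]1` gives 24%. The step of a number 23 percentage points higher from compound 1 to compound 2 (beyond the scatter) rests on a single change, (chloro in place of methyl on an aromatic carbon). Compound 3 `Cc1cccc(Nc2nc3c(=O)[nH]c(C)nc3s2)c1` belongs to a second core; how this core differs from that of compound 1 is not broken down here. In this assay compound 3 gives 12%, which lies between the other two measured values. Compound 4 `Cc1nc2sc(Nc3cccc(Cl)c3)nc2c(=O)[nH]1` is not yet measured and differs from compound 3 by chloro in place of methyl on an aromatic carbon, the same change, at the same place, as that from compound 1 to compound 2. The step is expected to be a number 18 percentage points higher from compound 3 to compound 4 (beyond the scatter) because the same change gave a number 23 percentage points higher from compound 1 to compound 2 (beyond the scatter). Compound 4 is accordingly estimated to give about 30%, expected to fall between 10% and 50%.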

Compound 4, a percentage reported as inhibition, at one concentration (the size of the read-out at that concentration, not a potency): 44%
Estimate against measurement, compound 4: 14 percentage points below; measured number inside the range.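

In this assay chloro in place of methyl on the second core gives a number 32 percentage points higher from compound 3 to compound 4 (beyond the scatter), the same direction as on the first core. The two steps cannot be told apart in size: the same change on two cores in this assay, a number 23 percentage points higher (beyond the scatter) from compound 1 to compound 2 and a number 32 percentage points higher (beyond the scatter) from compound 3 to compound 4, 9 percentage points apart, within the scatter of two such steps. The change therefore carries over between these two cores at this one place, but two pairs give no rule for any other core, and these numbers are inhibition at one concentration, not potencies.

Open, going by these compounds, is how an amine or a methoxy group at the same place would compare with chloro and methyl. Also open, on these data alone, is whether the step would hold if a longer chain replaced the methyl on the core.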